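A few compounds are considered here, and "the series" means these few. Any claim that something is new, unique, unknown or untested is made for them only; others in the source may bear on it.

Within the data shown here, compound 1 `Nc1cccc(Nc2nc(N/N=C/c3ccc(F)cc3)ncc2Cl)c1` and compound 2 `C=CC(=O)Nc1cccc(Nc2nc(N/N=C/c3ccc(F)cc3F)ncc2Cl)c1` share a core and differ at two places, so no single step between them is counted; in an ADME assay on HT-29 cells (Homo sapiens) for inhibition, read by MTT assay, with a stated time of 72 h (on this read-out lower numbers stand for stronger inhibition and higher numbers for weaker inhibition), compound 1 gives 12300 nM, while compound 2 gives 4760 nM. Of the two numbers seen so far, compound 2 stands at the lower one, and its gap to compound 1 lies beyond the usual scatter. Compound 3 `C=CC(=O)Nc1cccc(Nc2nc(N/N=C(\C)c3ccc(C)cc3)ncc2Cl)c1` is the next compound, not yet measured in this assay. It differs from compound 2 by a group of 10 heavy atoms (9 carbon, 1 nitrogen; one six-membered aromatic ring of carbon only) in place of a group of 10 heavy atoms (7 carbon, 1 nitrogen, 2 fluorine; one six-membered aromatic ring of carbon only), on a nitrogen on an aromatic ring. Among the measured compounds shown here, no step between measured compounds isolates this kind of change, so there is nothing in the data that shows its direction or size; the expectation rests only on compound 2 and its value 4760 nM in this assay. The step from compound 2 to compound 3 is therefore estimated as a 1.3-fold higher number from compound 2 to compound 3 (0.10 log units; within the scatter), a change not clearly beyond the scatter in either direction. For compound 3 the expected value in this assay is 6000 nM, with a range from 2000 nM to 18000 nM.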

Compound 3, half-maximal inhibitory concentration: 3210 nM
For compound 3 the middle estimate is 1.9-fold (0.27 log units) above the measured one; measured number inside the range.
By their numbers in this assay, from the lowest: compounds 3 and 2 (each within the scatter of the next); then compound 1.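

In this assay, among these compounds, the exchange on a nitrogen on an aromatic ring, where a group of 10 heavy atoms with 7 carbon, 1 nitrogen and 2 fluorine gives way to a group of 10 heavy atoms with 9 carbon and 1 nitrogen, comes to a 1.5-fold lower number from compound 2 to compound 3 (0.17 log units; within the scatter); this is the first single-place step at this position. Both groups hold one six-membered aromatic ring of carbon only and 1 double bond outside aromatic rings, and the step shows that this position accepts this exchange with no difference that stands clear of the scatter. Nothing in the material at hand accounts for this result.

Among the compounds shown here, the single step alters several atoms at once, so how much each part of the group contributes remains unresolved, and the step between compound 1 and compound 2 still cannot be divided between its two places. Going by these compounds, how this position would read with an amine or a carboxylic acid on the aromatic ring of the group also remains open.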